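The compounds below may be only part of what the source reports. "The series", "measured", "known", "first", "only" and "open" are said of these compounds alone.

Compound 1 `Clc1ccc(Cc2nn3c(Br)c(-c4ccc(Cl)cc4)nc3s2)cc1`: in a functional assay on HeLa cells (Homo sapiens) for cytotoxicity, with a stated time of 72 h (a higher number here means a weaker inhibitor, a lower number a stronger inhibitor), compound 1 gives > 250000 nM, which is a limit of the assay rather than a number.
Compound 2 `Clc1ccc(Cc2nn3c(Br)c(-c4ccccc4)nc3s2)cc1`: in this assay compound 2 gives > 250000 nM, again a limit.
Compound 3 `O=[N+]([O-])c1ccc(-c2nc3sc(Cc4ccc(Cl)cc4)nn3c2Br)cc1`: in this assay compound 3 gives > 250000 nM, again a limit.

Compound 1 therefore stands only at a limit, and so do the other two measured compounds, as the limit of > 250000 nM in this assay, at which 3 of the 3 values shown sit, shows. The steps a step that the two limits leave unreadable from compound 1 to compound 2, a step that the two limits leave unreadable from compound 1 to compound 3 and a step that the two limits leave unreadable from compound 2 to compound 3 all lie between limits and give no size.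

Compound 4 `N#CSc1c(-c2ccc(Cl)cc2)nc2sc(Cc3ccc(Cl)cc3)nn12` differs from compound 1 by cyanosulfanyl in place of bromo on an aromatic carbon. Within the data shown here, no measured step touches this position, and the three unreadable steps give no direction. Compound 4 is therefore expected to remain at or near the limit, estimated at 250000 nM, between 100000 nM and 1000000 nM. The expected step of a number no higher from compound 1 to compound 4 (the limit leaves the size open) is thus none beyond the scatter.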

Compound 4, half-maximal inhibitory concentration: 20000 nM
Estimate against measurement, compound 4: 13-fold (1.10 log units) above, outside the stated range (below it).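

In this assay, cyanosulfanyl in place of bromo on this aromatic carbon gives an at least 12-fold lower number from compound 1 to compound 4 (1.09 log units; beyond the scatter). Among these compounds, this is the first readable step; the steps among compound 1, compound 2 and compound 3 cannot be read. Only compound 4 has left the limit, so this position can move the read-out: the limit of > 250000 nM in this assay, at which 3 of the 4 values shown sit.

From the compounds shown here alone, whether the lower number needs the whole cyanosulfanyl group or only its sulfur or its nitrile stays open. So does what an amine or a methylsulfanyl group would give at this position.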